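The compounds below may be only part of what the source reports. "The series", "measured", "known", "first", "only" and "open" are said of these compounds alone.

Measured in an ADME assay on SH-SY5Y cells (Homo sapiens) for cytotoxicity, read by MTT assay, with a stated time of 72 h; on this read-out higher numbers stand for weaker inhibition and lower numbers for stronger inhibition:
- Compound 1 `O=C(CN1CCN(C(=O)c2ccccc2Br)CC1)N1CCN(CCCc2c[nH]c3ccc(F)cc23)CC1`: 79100 nM
- Compound 2 `COc1ccc2[nH]cc(CCCN3CCN(C(=O)CN4CCN(C(=O)c5ccc(Cl)cc5)CC4)CC3)c2c1`: 159000 nM
- Compound 3 `COc1ccc2[nH]cc(CCCN3CCN(C(=O)CN4CCN(C(=O)c5cccc(F)c5)CC4)CC3)c2c1`: > 200000 nM

Compound 3 gives > 200000 nM, which is only a limit of the assay and not a number. Compound 4 `COc1ccc2[nH]cc(CCCN3CCN(C(=O)CN4CCN(C(=O)c5ccccc5Br)CC4)CC3)c2c1` carries 2-bromophenyl in place of 3-fluorophenyl on a carbonyl carbon. Among the compounds with values here, the one measured step at this place is an at least 1.2-fold higher number from compound 2 to compound 3 (0.09 log units; that floor lies within the scatter), and its floor lies within the scatter, so it sets no firm size. Compound 1 carries the same 2-bromophenyl and gives 79100 nM, on a different core. A small move to a lower number, near the scatter, is therefore expected, an estimated at least 1.6-fold lower number from compound 3 to compound 4 (0.22 log units; that floor lies within the scatter). For compound 4 the estimated value is 120000 nM, with an expected range of 60000 nM to 200000 nM.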

Compound 4, half-maximal inhibitory concentration: 111000 nM
Estimate against measurement, compound 4: 1.1-fold (0.03 log units) above; measured number inside the range.
By their numbers in this assay, from the lowest: compounds 1, 4 and 2 (each within the scatter of the next). At a limit, above all of these: compound 3.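

In this assay compound 3 stands only at a limit of the assay, not at a number: the limit of > 200000 nM in this assay, at which 1 of the 4 values shown sits. On the carbonyl carbon, 2-bromophenyl gives an at least 1.8-fold lower number from compound 3 to compound 4 (0.25 log units; that floor lies within the scatter), and against 4-chlorophenyl it gives a 1.4-fold lower number from compound 2 to compound 4 (0.16 log units; within the scatter), so neither exchange establishes a change beyond the scatter. With 2-bromophenyl kept, methoxy in place of fluoro on an aromatic carbon gives a 1.4-fold higher number from compound 1 to compound 4 (0.15 log units; within the scatter), which shows that this second exchange also stays within the scatter.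

Still open, going by these compounds, is whether a phenyl carrying an amine or a carboxylic acid at this place would move the number beyond the scatter.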